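Notes on the amide-substituent series, compound 2 to compound 3

The source may hold more compounds than are shown below. What is called first, only, known or untested is meant among the compounds shown, and "the series" means these compounds.

Two measured compounds share one core and differ only in a single group on an aromatic carbon. Compound 1 `CCc1ccc(C(=O)Nc2cccc(-c3oc4cc(-c5ccc(F)cc5)ccc4c(=O)c3O)c2)cc1` carries ethyl there, and in a functional assay on HepG2 cells (Homo sapiens) for antiproliferative activity, read by CCK-8 assay, with a stated time of 72 h (on this read-out higher numbers stand for weaker inhibition and lower numbers for stronger inhibition), compound 1 gives 20600 nM. Compound 2 `O=C(Nc1cccc(-c2oc3cc(-c4ccc(F)cc4)ccc3c(=O)c2O)c1)c1ccc([N+](=O)[O-])cc1` carries nitro, and in this assay compound 2 gives 1860 nM, the lowest of the two numbers. The step of an 11-fold lower number from compound 1 to compound 2 (1.04 log units; beyond the scatter) was large. Compound 3 `CCCc1ccc(C(=O)Nc2cccc(-c3oc4cc(-c5ccc(F)cc5)ccc4c(=O)c3O)c2)cc1` is not yet measured; its difference from compound 2 is propyl in place of nitro on an aromatic carbon. For the measured compounds named here, the only measured step bearing on this change is an 11-fold lower number from compound 1 to compound 2 (1.04 log units; beyond the scatter), which ran in the opposite sense, from ethyl to nitro; propyl and ethyl are both alkyl chains, so the change to propyl is expected largely to undo that step, giving a large rise in this assay. The expected step is an 8.1-fold higher number from compound 2 to compound 3 (0.91 log units; beyond the scatter). Compound 3 is therefore estimated at 15000 nM, with a range of 5000 nM to 45000 nM.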

Compound 3, half-maximal inhibitory concentration: 51500 nM
Estimate against measurement, compound 3: 3.4-fold (0.54 log units) below, and the stated range ends below it.
By their numbers in this assay, from the lowest: compound 2; then compound 1; then compound 3.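

In this assay the two alkyl compounds do not read as one group: methyl in place of hydrogen on the chain gives a 2.5-fold higher number from compound 1 to compound 3 (0.40 log units; beyond the scatter) as a modest step beyond the scatter, so the length of the chain at this position moves the number by itself. Nitro to propyl gives a 28-fold higher number from compound 2 to compound 3 (1.44 log units; beyond the scatter) as a large step, which leaves nitro with the lowest number of the three groups and places both alkyl chains well above it, with propyl the higher of the two. No measurement is available that accounts for either step.

From the compounds shown here alone, whether a butyl or longer chain continues this rise remains open. Also open, going by these compounds, is whether a nitrile, an amine or a carboxylic acid on this aromatic carbon would stand nearer to compound 2 or to the alkyl compounds.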